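A Second Methoxy Group on the Shared Core

The source may hold more compounds than are shown below. What is called first, only, known or untested is meant among the compounds shown, and "the series" means these compounds.

Measured compounds:
compound 1, `CC(=O)c1cc(-c2ccccc2)cc2cc(-c3ccccc3)[nH]c12`, 51.4%
compound 2, `COc1ccc(-c2cc(C(C)=O)c3[nH]c(-c4ccccc4)cc3c2)cc1`, 21.1%

In a functional assay on HeLa cells (Homo sapiens) for cytotoxicity, read by MTT assay, with a stated time of 2 days, tested at 100 uM (a lower number here means a stronger effect, a higher number a weaker effect of the compound at the concentration tested), compound 1 gives 51.4%, while compound 2 gives 21.1%, the lowest of the two numbers, with compound 1 standing higher by a step beyond the scatter. Compound 3, `COc1ccc(-c2cc(C(C)=O)c3[nH]c(-c4ccc(OC)cc4)cc3c2)cc1`, differs from compound 2 in one place: methoxy in place of hydrogen on an aromatic carbon. For the measured compounds named here, the only measured step that bears on this change is a number 30.3 percentage points lower from compound 1 to compound 2 (beyond the scatter), the same replacement on the other aromatic ring. A further lowering is therefore expected, though compound 2 already leaves little room. Compound 3 is expected to show a number 7.1 percentage points lower from compound 2 to compound 3 (within the scatter). Compound 3 is estimated at 14%, within 4% to 30%.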

Compound 3, a percentage reported as activity, at one concentration (the size of the read-out at that concentration, not a potency): 20.2%
Compound 3: the middle estimate sits 6.2 percentage points below what was measured; the range from low to high includes it.
By their numbers in this assay, from the lowest: compounds 3 and 2 (each within the scatter of the next); then compound 1.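

In this assay the change from phenyl to 4-methoxyphenyl on this ring gives a number 0.9 percentage points lower from compound 2 to compound 3 (within the scatter) and so adds nothing measurable once the other ring carries its methoxy. The same replacement on the other ring gave a number 30.3 percentage points lower from compound 1 to compound 2 (beyond the scatter) and so does not carry over between the two places in this series. Nothing measured here accounts for this contrast between the two steps. Going by these compounds, it remains open whether an amine or a carboxylic acid in place of methoxy on this ring would read differently, and whether methoxy here would matter without the methoxy on the other ring.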